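The source may report more compounds than this note shows. Statements on the series, on what has been measured and on what is new or still open speak of the compounds shown alone.

Three pyrazoline compounds have been measured in a functional assay on HEp-2 cells (Homo sapiens) for cytotoxicity, read by sulforhodamine B assay, with a stated time of 48 h; a higher number here means a weaker inhibitor, a lower number a stronger inhibitor. Compound 1 `CC(=O)N1N=C(c2ccccc2)CC1c1cccc(Cl)c1Cl` gives 24000 nM. Compound 2 `CC(=O)N1N=C(c2ccc(Br)cc2)CC1c1cccc(Cl)c1Cl` gives 50000 nM, the highest of the three numbers, and compound 3 `CC(=O)N1N=C(c2ccco2)CC1c1ccccc1[N+](=O)[O-]` gives 47900 nM, which lies within the scatter of compound 2. Going by the values given here, the one step between compounds that differ in a single place is a 2.1-fold higher number from compound 1 to compound 2 (0.32 log units; beyond the scatter).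

Compound 4 `CC(=O)N1N=C(c2ccco2)CC1c1cccc(Cl)c1Cl` has not yet been measured in this assay. It differs from compound 2 in one place: furan-2-yl in place of 4-bromophenyl on a carbon with a double bond to nitrogen. Among the compounds with values here, no measured step makes exactly this change. Within the data shown here, the only step that bears on it, a 2.1-fold higher number from compound 1 to compound 2 (0.32 log units; beyond the scatter), shows that the bromine on the 4-bromophenyl group went with a modestly higher number, and compound 4 carries no bromine; at the same time compound 3, which bears the same furan-2-yl group, gives 47900 nM. Taken together, a small step toward a lower number is expected, a 1.6-fold lower number from compound 2 to compound 4 (0.19 log units; within the scatter), but one that may stay within the scatter. Compound 4 is therefore estimated at 32000 nM, with a range from 13000 nM to 80000 nM.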

Compound 4, half-maximal inhibitory concentration: 43200 nM
The estimate for compound 4 lay 1.4-fold (0.13 log units) below the measured number, within the range that was stated.
By their numbers in this assay, from the lowest: compounds 1, 4, 3 and 2 (each within the scatter of the next, the first and the last beyond it).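

At the carbon with a double bond to nitrogen, furan-2-yl can stand in for either six-membered aromatic ring without a change that can be read in this assay: the swap gives a 1.2-fold lower number from compound 2 to compound 4 (0.06 log units; within the scatter) and a 1.8-fold higher number from compound 1 to compound 4 (0.26 log units; within the scatter). So this position accepts a five-membered aromatic ring with 1 hetero atom, which has fewer heavy atoms and adds a hydrogen-bond acceptor, with both steps staying within the scatter of this measurement. No measurement at hand explains this result.

Going by these compounds, whether an amine, a carboxylic acid or a longer chain on this same carbon would give a step beyond the scatter remains open. On these data alone, it is also open whether thiophene-2-yl, with sulfur in place of the furan oxygen, would behave as furan-2-yl does.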